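The source may hold more compounds than are shown below. What is called first, only, known or untested is meant among the compounds shown, and "the series" means these compounds.

Measured compounds:
- compound 1, `COc1cc(Cl)cc(-c2nn(-c3cccc(NC(=O)Nc4ccc(Cl)c(Cl)c4)c3)cc2-c2ccncc2)c1`: 92%
- compound 2, `COc1cc(Cl)cc(-c2nn(-c3cccc(NC(=O)Nc4cccc(C(F)(F)F)c4)c3)cc2-c2ccncc2)c1`: 98%

Both compounds were tested in a functional assay on SNB-19 cells (Homo sapiens) for inhibition, read by sulforhodamine B assay, with a stated time of 48 h, tested at 0.01 uM; a higher number here means a weaker effect of the compound at the concentration tested, a lower number a stronger effect. Compound 1 gives 92% in this assay, and compound 2 gives 98%. Within the data shown here, compound 2 stands alongside compound 1: the only step among the measured pair, a number 6 percentage points higher from compound 1 to compound 2 (within the scatter), does not rise above the scatter, so the two numbers cannot be told apart, and both show that at this concentration little of the cell growth is held back.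

Compound 3, `COc1cc(Cl)cc(-c2nn(-c3cccc(NC(=O)c4cccc(C(F)(F)F)c4)c3)cc2-c2ccncc2)c1`, has not yet been measured. It differs from compound 2 in one place: 3-(trifluoromethyl)phenyl in place of (3-(trifluoromethyl)phenyl)amino on a carbonyl carbon. Among the measured compounds shown here, the one measured step, a number 6 percentage points higher from compound 1 to compound 2 (within the scatter), changes the group on the amide-type nitrogen, not the carbonyl carbon, so it bears only loosely on this change; it does show that swapping groups in this part of the molecule left this assay unmoved. For the measured compounds named here, no measured step touches the linkage itself. On that basis compound 3 is expected to give 95% in this assay, within 82% to 105%, which means an expected step of a number 3 percentage points lower from compound 2 to compound 3 (within the scatter) from compound 2, not beyond the scatter.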

Compound 3, a percentage reported as activity, at one concentration (the size of the read-out at that concentration, not a potency): 96%
Compound 3: the middle estimate sits 1 percentage points below what was measured; low and high end bracket the measured number.
By their numbers in this assay, from the lowest: compounds 1, 3 and 2 (each within the scatter of the next).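

In this assay, replacing (3-(trifluoromethyl)phenyl)amino with 3-(trifluoromethyl)phenyl on the carbonyl carbon removes the nitrogen and the hydrogen-bond donor of the leaving group, and the result is a number 2 percentage points lower from compound 2 to compound 3 (within the scatter). Among these compounds, the linkage, which no earlier step had touched, can therefore be altered here without a shift that stands out from the scatter, and the same holds when the aryl group changes along with it, in a number 4 percentage points higher from compound 1 to compound 3 (within the scatter), where 3-(trifluoromethyl)phenyl stands in place of (3,4-dichlorophenyl)amino. Nothing available speaks to why this change leaves the read-out where it is.

All three compounds hold back little of the cell growth at this single concentration, so the compounds shown leave open whether the nitrogen of the linkage matters at concentrations where growth is clearly held back. Also open, on these data alone, is how the read-out would respond if the carbonyl carbon carried a saturated amine such as morpholine, or a longer carbon chain ending in a carboxylic acid, in place of the aryl groups seen so far.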